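Methyl-to-cyano swap on the pyridine of compound 3

The compounds below may be only part of what the source reports. "The series", "measured", "known", "first", "only" and "open" are said of these compounds alone.

Measured compounds:
compound 1 `N#Cc1cccc(C#Cc2cccc(C#N)n2)c1`: 20 nM
compound 2 `N#Cc1cc(F)cc(C#Cc2cccc(F)n2)c1`: 80 nM
compound 3 `Cc1cccc(C#Cc2cc(F)cc(C#N)c2)n1`: 2.4 nM

In an in vitro functional assay on HEK293-A cells for agonist activity at metabotropic glutamate receptor 5 (Rattus norvegicus), read by ELISA (on this read-out lower numbers stand for stronger inhibition and higher numbers for weaker inhibition), compound 3 gives the lowest number of the three, with compound 1 the nearest and compound 2 the furthest. Within the data shown here, the one single-point step measured, a 33-fold lower number from compound 2 to compound 3 (1.52 log units; beyond the scatter), shows how much a methyl on the pyridine ring matters. Compound 4 `N#Cc1cc(F)cc(C#Cc2cccc(C#N)n2)c1` carries cyano in place of methyl on an aromatic carbon. Among the measured compounds shown here, no measured step covers this exact exchange. Compound 1 and compound 4 share the cyano group next to the ring nitrogen, and compound 1 sits well above compound 3. Removing the methyl is therefore expected to cost potency, giving a 6.3-fold higher number from compound 3 to compound 4 (0.80 log units; beyond the scatter). The estimate for compound 4 in this assay is 15 nM, within 4 nM to 60 nM.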

Compound 4, half-maximal inhibitory concentration: 9 nM
Compound 4: middle estimate off by 1.7-fold (0.22 log units), on the high side, within the range that was stated.
By their numbers in this assay, from the lowest: compound 3; then compound 4; then compound 1; then compound 2.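

In this assay, at this position next to the ring nitrogen, cyano in place of methyl gives a 3.8-fold higher number from compound 3 to compound 4 (0.57 log units; beyond the scatter) and cyano in place of fluoro gives an 8.9-fold lower number from compound 2 to compound 4 (0.95 log units; beyond the scatter), so the order here runs methyl, cyano, fluoro, lowest number first. Elsewhere, with cyano held at this position, fluoro in place of hydrogen gives a 2.2-fold lower number from compound 1 to compound 4 (0.35 log units; beyond the scatter) as a further modest gain. Nothing on hand accounts for this order.

Open, going by these compounds, is whether an amine or a methoxy group at this position would give a number under that of compound 3. Also open, on these data alone, is whether the fluoro gain holds with methyl in place of cyano.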